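Adding a chloro group to compound 1

The source may report more compounds than this note shows. Statements on the series, on what has been measured and on what is new or still open speak of the compounds shown alone.

Measured so far:
- compound 1 `Cc1ccccc1-c1nc(CN2CCC(C(=O)NCCCN3CCC(C)(C)CC3)CC2)c(C)o1`: > 69 ug/mL
- compound 2 `Cc1ccccc1-c1nc(CN2CCC(C(=O)NCCCN3CCC(C)CC3)CC2)c(C)o1`: > 67 ug/mL

In a physicochemical assay for solubility, in phosphate buffer, measured as kinetic solubility, at pH 7.4 (a lower number here means a less soluble compound, a higher number a more soluble compound), compound 1 gives > 69 ug/mL, which is a limit and not a number. Compound 2 gives > 67 ug/mL, which is also a limit. Compound 1 therefore has no exact value, and the only other result offers no exact comparison.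

Compound 3 `Cc1cccc(Cl)c1-c1nc(CN2CCC(C(=O)NCCCN3CCC(C)(C)CC3)CC2)c(C)o1` differs from compound 1 by chloro in place of hydrogen on an aromatic carbon, turning 2-methylphenyl into 2-chloro-6-methylphenyl. Going by the values given here, the only measured step is a step that the two limits leave unreadable from compound 1 to compound 2. It involves hydrogen in place of methyl on a saturated ring carbon, not an aromatic carbon, and gives no size to carry over. A small downward step in this assay is expected, or none beyond the scatter. The expected change is an at least 1.1-fold lower number from compound 1 to compound 3 (0.06 log units; that floor lies within the scatter). For compound 3 the estimate is 60 ug/mL, with an expected range of 28 ug/mL to 80 ug/mL.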

Compound 3, solubility: > 74 ug/mL
Compound 3 was reported as a limit; the forecaster's own chance of this, stated with the estimate: 60%; middle value at least 1.2-fold (0.09 log units) from the limit.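

Compound 1 and compound 3 are both reported only as limits in this assay, so the step between them cannot be read. The compounds shown leave open the exact number for each compound, and whether 2-chloro-6-methylphenyl in place of 2-methylphenyl shifts that number at all.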